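Iodo replaces methylsulfanyl on the five-membered ring

The source may report more compounds than this note shows. Statements on the series, on what has been measured and on what is new or still open speak of the compounds shown alone.

Compound 3 `CSc1nc2c(N)ncnc2n1Cc1ccccc1` sits at a limit of a functional assay (spleen, spleen) for activation, with Mus musculus as the target; a higher number here means that more compound is needed for the effect, a lower number that less compound is needed: in this assay compound 3 gives > 10 uM, a limit and not a number. Compound 1 `Nc1ncnc2c1nc(Cl)n2Cc1ccccc1` also reaches only a limit, giving > 10 uM in this assay. Among the measured compounds shown here, the single measured step that touches the position of interest, a step that the two limits leave unreadable from compound 1 to compound 3, cannot be read in either direction because of the limit of > 10 uM in this assay, at which 2 of the 3 values shown sit. For the measured compounds named here, compound 2 `CCOc1nc(N)c2nc(O)n(Cc3ccccc3)c2n1`, with ethoxy and hydroxy on its core, gives 0.1 uM in this assay, but no step links it to compound 3 in a single change.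

The next compound, compound 4 `Nc1ncnc2c1nc(I)n2Cc1ccccc1`, differs from compound 3 as follows: iodo in place of methylsulfanyl on an aromatic carbon. Compound 1 shows that a halogen at this carbon of the shared core can sit at the limit, and compound 3 shows that methylsulfanyl does too; the size of any step from one to the other is not readable. Going by the values given here, no measured step therefore gives a direction for the change to iodo, and the expectation is that compound 4 stays near the limit as well. Compound 4 is expected to give about 30 uM in this assay, within 5 uM to 200 uM, which means an expected step that the limit leaves unreadable from compound 3 to compound 4 that would most likely again be reported only as a limit.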

Compound 4, minimum effective concentration: > 10 uM
Compound 4 was reported as a limit (the forecaster's own chance of this, stated with the estimate: 75%); the middle value lies beyond the limit too.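

The steps to compound 4 from compound 3 and from compound 1 cannot be read, because all three compounds sit at a limit in this assay: the limit of > 10 uM in this assay, at which 3 of the 4 values shown sit.

The compounds shown leave open how chloro, methylsulfanyl and iodo on this aromatic carbon rank, and which single changes lead from the shared core towards compound 2, at 0.1 uM.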